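This account rests on a few compounds, and the source may have more. Where it says the series, first, only, none or still open, it means among the compounds named here.

In a functional assay on MCF7 cells (Homo sapiens), tested at 5 uM (on this read-out lower numbers stand for a stronger effect and higher numbers for a weaker effect at the one concentration tested), compound 1 `CC(C)=CCOc1c(C)c(C)c2c(c1C)CCC(C)(COc1ccc(/C=C3\SC(=O)NC3=O)cc1F)O2` gives 87%. Compound 2 `C=CCOc1c(C)c(C)c2c(c1C)CCC(C)(COc1ccc(/C=C3\SC(=O)NC3=O)cc1OCC)O2` carries an ethoxy group and an allyloxy group where compound 1 carries fluorine and the longer ether. In this assay compound 2 gives a reading of 87%, level with compound 1 within the scatter. Compound 3 `CCOc1cc(/C=C2\SC(=O)NC2=O)ccc1OCC1(C)CCc2c(C)c(OCC=C(C)C)c(C)c(C)c2O1` differs from compound 2 by 2-methylprop-1-en-1-yl in place of vinyl on a saturated chain carbon bound to an oxygen on an aromatic ring. With both measured compounds standing at the same reading, no shift beyond the scatter is expected for the step of no change at the digits printed from compound 2 to compound 3 (within the scatter) in this assay. Compound 3 is therefore estimated at 87%, in a range from 72% to 100%.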

Compound 3, a percentage reported as activity, at one concentration (the size of the read-out at that concentration, not a potency): 84%
Estimate against measurement, compound 3: 3 percentage points above; the range from low to high includes it.
By their numbers in this assay, from the lowest: compounds 3, 1 and 2 (each within the scatter of the next).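

In this assay, 2-methylprop-1-en-1-yl in place of vinyl, which turns allyloxy into (3-methylbut-2-en-1-yl)oxy, gives a number 3 percentage points lower from compound 2 to compound 3 (within the scatter), and ethoxy in place of fluoro on an aromatic carbon gives a number 3 percentage points lower from compound 1 to compound 3 (within the scatter). Compound 1 and compound 2 differ in both places at once, so compound 3 is what lets each change be read alone. Nothing available explains these readings. The compounds shown leave open whether an amine in place of ethoxy on that aromatic carbon, or a longer chain on the oxygen, would move the reading beyond the scatter.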